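The compounds below may be only part of what the source reports. "The series", "measured", "known", "first", "only" and "open" are said of these compounds alone.

Working notes on the series in a functional assay on SMMC-7721 cells (Homo sapiens) for cytotoxicity, read by MTT assay, with a stated time of 72 h; on this read-out lower numbers stand for stronger inhibition and higher numbers for weaker inhibition. Compound 1 `O=C1C(=Cc2ccc(Cl)cc2)C(=O)N(c2ccc(Cl)cc2)N1c1ccc(Cl)cc1` gives 30900 nM, compound 2 `COc1cccc(C=C2C(=O)N(c3ccc(Cl)cc3)N(c3ccc(Cl)cc3)C2=O)c1` gives 30200 nM and compound 3 `O=C1C(=Cc2ccco2)C(=O)N(c2ccc(Cl)cc2)N1c1ccc(Cl)cc1` gives 19500 nM. Compound 3 is not separated from the other two, as all three values lie within the scatter of one another.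

The next compound is compound 4 `O=C1C(=C/C=C/c2ccccc2)C(=O)N(c2ccc(Cl)cc2)N1c1ccc(Cl)cc1`, with the change 2-phenylethenyl in place of furan-2-yl on a double-bonded chain carbon bound to a double-bonded ring carbon.

Among the measured compounds shown here, three measured steps bear on this place: a 1.0-fold lower number from compound 1 to compound 2 (0.01 log units; within the scatter), a 1.6-fold lower number from compound 1 to compound 3 (0.20 log units; within the scatter) and a 1.5-fold lower number from compound 2 to compound 3 (0.19 log units; within the scatter). All three stay within the scatter. For the measured compounds named here, no measured compound carries 2-phenylethenyl here, so the data test this group only indirectly. No step beyond the scatter is therefore expected in this assay, and no direction is favoured, although the range is kept wide.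

The expected step is a 1.0-fold higher number from compound 3 to compound 4 (0.01 log units; within the scatter). For compound 4 the estimated value is 20000 nM, with an expected range from 7000 nM to 50000 nM.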

Compound 4, half-maximal inhibitory concentration: 10100 nM
Compound 4: the middle estimate sits 2.0-fold (0.30 log units) above what was measured; measured number inside the range.
By their numbers in this assay, from the lowest: compounds 4, 3, 2 and 1 (each within the scatter of the next, the first and the last beyond it).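

In this assay this position now gives steps beyond the scatter: 2-phenylethenyl gives a 3.0-fold lower number from compound 2 to compound 4 (0.48 log units; beyond the scatter) and a 3.1-fold lower number from compound 1 to compound 4 (0.49 log units; beyond the scatter), both modest, whereas the exchanges among 4-chlorophenyl, 3-methoxyphenyl and furan-2-yl all stayed within the scatter. Against furan-2-yl, the same group gives a 1.9-fold lower number from compound 3 to compound 4 (0.29 log units; within the scatter), so compound 4 is separated from compound 1 and compound 2 but not from compound 3. No measured information accounts for these steps.

The compounds shown leave open whether the modest steps follow the double bond of 2-phenylethenyl or its phenyl ring, a question that the saturated 2-phenylethyl chain would address. Also open, from the compounds shown here alone, is how a longer chain, such as 4-phenylbuta-1,3-dienyl, or a group carrying an amine or a carboxylic acid would read at this place.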